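The source may hold more compounds than are shown below. What is called first, only, known or untested is meant among the compounds shown, and "the series" means these compounds.

Working notes on the series

Compound 1 `CC1(C)C=C(n2ccccc2=O)c2cc(C(=O)c3ccccc3F)ccc2O1` gives 6.34 in a functional assay (trachea) with Rattus norvegicus as the target; a higher number here means a more potent compound, by a factor of ten per unit of this negative logarithm, a lower number a less potent compound. Compound 2 `CC1(C)C=C(n2ccccc2=O)c2cc(C(=O)c3c(F)cccc3F)ccc2O1` carries the change fluoro in place of hydrogen on an aromatic carbon and gives 5.99 in this assay; the step of a number 0.35 log units lower from compound 1 to compound 2 (beyond the scatter) is modest. Compound 3 `CC1(C)C=C(n2ccccc2=O)c2cc(OC(=O)Nc3ccccc3)ccc2O1` has a different core; how the two cores differ is not broken down here. In this assay compound 3 gives 4.89, the lowest of the three numbers. Compound 4 `CC1(C)C=C(n2ccccc2=O)c2cc(OC(=O)Nc3ccccc3F)ccc2O1` is the unmeasured member and differs from compound 3 by fluoro in place of hydrogen on an aromatic carbon. This is the same kind of change as from compound 1 to compound 2, though the place is not identical: in compound 2 the entering fluoro is also meta to a fluoro group, while in compound 4 it is not. Within the data shown here, with only that one earlier step to rest on, the step of a number 0.34 log units lower from compound 3 to compound 4 (beyond the scatter) is expected to be of similar size, because a number 0.35 log units lower from compound 1 to compound 2 (beyond the scatter) was modest. Compound 4 is therefore estimated at 4.55, with a likely range of 4 to 5.1.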

Compound 4, logarithm of the reciprocal of the active concentration, log(1/C): 4.22
For compound 4 the middle estimate is 0.33 log units above the measured one, within the range that was stated.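

In this assay, fluoro in place of hydrogen on an aromatic carbon gives a number 0.67 log units lower from compound 3 to compound 4 (beyond the scatter). Set beside the earlier step, the change lowers the number on both cores, and the two sizes cannot be told apart: the same change on two cores in this assay, a number 0.35 log units lower (beyond the scatter) from compound 1 to compound 2 and a number 0.67 log units lower (beyond the scatter) from compound 3 to compound 4, 0.32 log units apart, within the scatter of two such steps

This rests on a single pair per core, so it does not show that the step would carry over to any further core, or that the place of the fluoro on the ring is without influence.

The compounds shown leave open how chloro, methyl or methoxy in the same place would read in this assay on either core. Also open, on these data alone, is whether the carbamoyl linkage of compound 3 tolerates a pyridyl ring in place of its phenyl.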